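Bromo substitution on the isatin-derived core: expectation before assay

The source may hold more compounds than are shown below. What is called first, only, known or untested is meant among the compounds shown, and "the series" means these compounds.

Compounds measured so far, with values from a functional assay on Hs 683 cells (Homo sapiens) for antiproliferative activity, read by MTT assay, with a stated time of 72 h; a higher number here means a weaker inhibitor, a lower number a stronger inhibitor:
- compound 1, `O=C1Nc2c(F)cccc2/C1=C1/Nc2ccccc2C1=O`, gives 38700 nM
- compound 2, `O=C1NC(=O)/C(=C2/C(=O)Nc3ccccc32)N1`, gives 84700 nM
- compound 3, `O=C1NC(=S)N/C1=C1\C(=O)Nc2ccccc21`, gives 52900 nM

All three numbers sit close together. Compound 3 stands between the other two: its gap to compound 1 and its gap to compound 2 are both within the usual scatter of this assay, so no order among the three can be read from these values. Among the compounds with values here, no single-point step between measured compounds is available in this set.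

Compound 4, `O=C1NC(=S)N/C1=C1\C(=O)Nc2c(Br)cccc21`, is the next member. Relative to compound 3 the change is bromo in place of hydrogen on an aromatic carbon. Within the data shown here, nothing among the measured compounds isolates the effect of a bromo at this position on the shared core, so no step size can be drawn from them. The working expectation is a step from compound 3 to compound 4 of a 1.3-fold lower number from compound 3 to compound 4 (0.12 log units; within the scatter), i.e. no change beyond the scatter. Compound 4 is estimated at 40000 nM in this assay, with a range of 15000 nM to 110000 nM.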

Compound 4, half-maximal inhibitory concentration: 40800 nM
Estimate against measurement, compound 4: 1.0-fold (0.01 log units) below; the range from low to high includes it.
By their numbers in this assay, from the lowest: compounds 1, 4, 3 and 2 (each within the scatter of the next, the first and the last beyond it).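

In this assay, bromo in place of hydrogen on an aromatic carbon, ortho to a fused ring and meta to a fused ring, gives a 1.3-fold lower number from compound 3 to compound 4 (0.11 log units; within the scatter). Within the data shown here, this is the first single-point step, and it shows that this position carries a bromo with no change that can be read beyond the scatter. No supporting evidence bears on this result.

Going by these compounds, whether an amine or a carboxylic acid on this same aromatic carbon would move the number beyond the scatter remains open. Also open, on these data alone, is whether a bromo on the other aromatic carbons of this six-membered ring, or on the shared core with a carbonyl in place of the thiocarbonyl, as in compound 2, would behave the same way.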